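The source may hold more compounds than are shown below. What is called first, only, known or untested is meant among the compounds shown, and "the series" means these compounds.

Measured compounds in an ADME assay for inhibition of prostaglandin G/H synthase 1 (Rattus norvegicus), with a stated time of 30 min; on this read-out higher numbers stand for weaker inhibition and lower numbers for stronger inhibition:
Compound 1 `CN1C=CN(C2OC(C(F)(F)F)=CN2c2ccc(S(N)(=O)=O)cc2)C=C1` gives 55600 nM.
Compound 2 `CN1C=CC(C2SC(C(F)(F)F)=CN2c2ccc(S(N)(=O)=O)cc2)C=C1` gives 80500 nM.
Compound 3 `CN1C=CN(C2OC(C(Cl)(Cl)Cl)=CN2c2ccc(S(N)(=O)=O)cc2)C=C1` gives 53400 nM.

Among these, compound 1 has the second highest number, and its gaps to compound 3 and to compound 2 both fall within the scatter. Among the compounds with values here, the only single-point step measured here, a 1.0-fold lower number from compound 1 to compound 3 (0.02 log units; within the scatter), shows that swapping the trifluoromethyl for trichloromethyl left this assay essentially unchanged.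

Compound 4 `CN1C=CC(C2OC(C(F)(F)F)=CN2c2ccc(S(N)(=O)=O)cc2)C=C1` differs from compound 1 by a group of 7 heavy atoms (6 carbon, 1 nitrogen; one six-membered non-aromatic ring with 1 hetero atom) in place of a group of 7 heavy atoms (5 carbon, 2 nitrogen; one six-membered non-aromatic ring with 2 hetero atoms), on a saturated ring carbon. Within the data shown here, no measured step covers this exact change. Compound 2 carries the same entering group on a related core and gives 80500 nM, close to compound 1. The expected step of a 1.2-fold higher number from compound 1 to compound 4 (0.07 log units; within the scatter) is therefore none beyond the scatter, and compound 4 is estimated at 65000 nM, within 30000 nM to 140000 nM.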

Compound 4, half-maximal inhibitory concentration in the prostaglandin G/H synthase 1 assay: 50200 nM
Estimate against measurement, compound 4: 1.3-fold (0.11 log units) above; the range from low to high includes it.
By their numbers in the prostaglandin G/H synthase 1 assay, from the lowest: compounds 4, 3, 1 and 2 (each within the scatter of the next).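

Within the data shown here, in the prostaglandin G/H synthase 1 assay, placing the group with one hetero atom in its six-membered ring on the saturated ring carbon of the unchanged core gives a 1.1-fold lower number from compound 1 to compound 4 (0.04 log units; within the scatter), with compound 4 at 50200 nM, the first direct reading of this swap, which earlier could only be inferred from a related core. In a physicochemical assay for acid dissociation, the same change gives a number 0.15 log units higher from compound 1 to compound 4 (within the scatter), with compound 1 at 7.18 and compound 4 at 7.33, so neither read-out separates the two groups. Nothing available explains this absence of a difference. As far as these compounds go, whether an amine or a carboxylic acid on this carbon would move either number beyond the scatter remains open.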